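The source may hold more compounds than are shown below. What is called first, only, known or untested is meant among the compounds shown, and "the series" means these compounds.

Three compounds share one core and differ only in the substituted phenyl ring on a double-bonded chain carbon. Compound 1 `CC/C(=C(/c1ccc(/C=C/C(=O)O)cc1)c1cc2ccccc2[nH]1)c1ccc(C#N)cc1Cl` gives 49 nM in a functional assay on MCF7 cells (Homo sapiens) for inhibition; a lower number here means a stronger inhibitor, a higher number a weaker inhibitor. Compound 2 `CC/C(=C(/c1ccc(/C=C/C(=O)O)cc1)c1cc2ccccc2[nH]1)c1ccc(C(F)(F)F)cc1Cl` gives 27 nM in this assay; it differs from compound 1 by trifluoromethyl in place of cyano on an aromatic carbon, a change that made a step of a 1.8-fold lower number from compound 1 to compound 2 (0.26 log units; within the scatter). Compound 3 `CC/C(=C(/c1ccc(/C=C/C(=O)O)cc1)c1cc2ccccc2[nH]1)c1ccc(Cl)cc1C#N` gives 14 nM in this assay, and its core differs from that of compound 1 by 4-chloro-2-cyanophenyl in place of 2-chloro-4-cyanophenyl on a double-bonded chain carbon bound to a double-bonded chain carbon and a saturated chain carbon.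

Compound 4 `CC/C(=C(/c1ccc(/C=C/C(=O)O)cc1)c1cc2ccccc2[nH]1)c1ccc(Cl)cc1C(F)(F)F` has not yet been measured. It differs from compound 3 by trifluoromethyl in place of cyano on an aromatic carbon. This is the same kind of change as from compound 1 to compound 2, not the same one, since the surroundings differ: in compound 1 the place is meta to a chloro group and para to a large group, whereas in compound 3 it is ortho to a large group and meta to a chloro group. Because the earlier step of a 1.8-fold lower number from compound 1 to compound 2 (0.26 log units; within the scatter) stayed within the scatter, a step of similar size is expected here, with added uncertainty from the different surroundings. Compound 4 is therefore expected to give about 9 nM in this assay, likely between 4 nM and 25 nM. The step this estimate implies for compound 4 is a 1.6-fold lower number from compound 3 to compound 4 (0.19 log units; within the scatter), an expectation rather than a measurement.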

Compound 4, half-maximal inhibitory concentration: 4 nM
Compound 4: the middle estimate sits 2.3-fold (0.35 log units) above what was measured, within the range that was stated.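

In this assay, trifluoromethyl in place of cyano gives a 3.5-fold lower number from compound 3 to compound 4 (0.54 log units; beyond the scatter), and the two cores cannot be told apart on the size of this change: the same change on two cores in this assay, a 1.8-fold lower number (0.26 log units; within the scatter) from compound 1 to compound 2 and a 3.5-fold lower number (0.54 log units; beyond the scatter) from compound 3 to compound 4, 1.9-fold (0.29 log units) apart, within the scatter of two such steps. This fits the change carrying over from one core to the other, but two pairs are a thin basis, and a real difference between the cores smaller than the scatter cannot be ruled out. Going by these compounds alone, the other steps to compound 4 swap the whole ring, with a 6.8-fold lower number from compound 2 to compound 4 (0.83 log units; beyond the scatter) and a 12-fold lower number from compound 1 to compound 4 (1.09 log units; beyond the scatter), which makes compound 4 the strongest inhibitor of the four, though these steps say nothing about the single change on any further core.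

The compounds shown leave open how other groups at the same place would behave, such as a methoxy group, a methyl group or an amine. They also leave open whether the result would hold with an amide in place of the carboxylic acid.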